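Chloro for Nitro on the Fused Ring

This account rests on a few compounds, and the source may have more. Where it says the series, first, only, none or still open, it means among the compounds named here.

Three measured compounds share one core and differ only in the group on the fused ring: compound 1 `Cc1ccc2nc(NC(=O)CNC(=O)c3nn(-c4ccccc4)c(=O)c4ccccc34)sc2c1`, compound 2 `CCOC(=O)c1ccc2nc(NC(=O)CNC(=O)c3nn(-c4ccccc4)c(=O)c4ccccc34)sc2c1` and compound 3 `O=C(CNC(=O)c1nn(-c2ccccc2)c(=O)c2ccccc12)Nc1nc2ccc([N+](=O)[O-])cc2s1`. In an assay on L cells for inhibition of Protein-serine O-palmitoleoyltransferase porcupine (Mus musculus), read by reporter gene assay, with a stated time of 24 h (a lower number here means that less compound is needed, a higher number that more compound is needed for the effect), compound 1 gives 35 nM. Compound 3 gives 240 nM, the highest of the two numbers shown, reached through the step of a 6.9-fold higher number from compound 1 to compound 3 (0.84 log units; beyond the scatter). For compound 2 the assay reports only a limit, > 25000 nM (the limit of > 25000 nM in this assay, at which 1 of the 3 values shown sits). The step of an at least 710-fold higher number from compound 1 to compound 2 (2.85 log units; beyond the scatter) is large, and so is the step of an at least 100-fold lower number from compound 2 to compound 3 (2.01 log units; beyond the scatter), both involving ethoxycarbonyl at this position.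

Compound 4 `O=C(CNC(=O)c1nn(-c2ccccc2)c(=O)c2ccccc12)Nc1nc2ccc(Cl)cc2s1` carries the change (chloro in place of nitro on an aromatic carbon). Chloro enters as one heavy atom while nitro leaves with three, so the change strips the position down rather than building it out, the direction in which compound 1 sits with its methyl. Among the measured compounds shown here, no measured step includes a halogen, so the steps from compound 1 to compound 3 and from compound 1 to compound 2 are the only guides, and they suggest that a compact group at this position keeps the number low. He therefore expects a modest lowering, a 4.0-fold lower number from compound 3 to compound 4 (0.60 log units; beyond the scatter), for compound 4, estimated at 60 nM within a range from 15 nM to 300 nM.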

Compound 4, half-maximal effective concentration: 30 nM
Compound 4: middle estimate off by 2.0-fold (0.30 log units), on the high side, within the range that was stated.
By their numbers in this assay, from the lowest: compounds 4 and 1 (each within the scatter of the next); then compound 3. At a limit, above all of these: compound 2.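

In this assay, chloro in place of nitro gives an 8.0-fold lower number from compound 3 to compound 4 (0.90 log units; beyond the scatter), and this first halogen at the position shows that a single heavy atom can stand there with no loss relative to methyl. The two small groups cannot be told apart, with a 1.2-fold lower number from compound 1 to compound 4 (0.07 log units; within the scatter), so the position now holds two different compact groups at one level, with nitro higher than both. The step of an at least 830-fold lower number from compound 2 to compound 4 (2.92 log units; beyond the scatter) is large, but it rests on the value of compound 2, which is a limit and not a number: the limit of > 25000 nM in this assay, at which 1 of the 4 values shown sits.

The compounds shown leave open whether that level extends to other small groups such as fluoro, methoxy or an amine, and whether the ethoxycarbonyl result follows from the length of the group or from its ester, a question that a carboxylic acid or a longer alkyl chain at this position would help to separate. From the compounds shown here alone, all four compounds also keep the rest of the shared core unchanged, so it remains open whether chloro and methyl would still match with a different group elsewhere on it.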